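The compounds below may be only part of what the source reports. "The series", "measured", "known", "first", "only" and "open" are said of these compounds alone.

Working notes on the series. In a functional assay on DU-145 cells (Homo sapiens) for cytotoxicity, read by sulforhodamine B assay, with a stated time of 48 h (a higher number here means that more compound is tolerated, a lower number that less compound is tolerated), compound 2, structure `CC(=O)N1CCN(c2nc(Nc3ccc(C#N)c(C(F)(F)F)c3)nc(Oc3ccnc4ccccc34)n2)CC1`, reaches only the limit of the assay, recorded as > 100000 nM. The same holds for compound 1, structure `N#Cc1ccc(Nc2nc(Oc3ccnc4ccccc34)nc(N3CCN(C(c4ccccc4)c4ccc(Cl)cc4)CC3)n2)cc1C(F)(F)F`, which in this assay gives > 100000 nM, again a limit and not a number. Among the compounds with values here, both measured values therefore sit at the limit of > 100000 nM in this assay, at which 2 of the 2 values shown sit, so compound 2 stands at the same place as everything else measured here, and no step between measured compounds can be read off.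

Compound 3, structure `COc1ccc(N2CCN(c3nc(Nc4ccc(C#N)c(C(F)(F)F)c4)nc(Oc4ccnc5ccccc45)n3)CC2)cc1`, is not yet measured. It differs from compound 2 by 4-methoxyphenyl in place of acetyl on an amine nitrogen in a ring. With compound 1 and compound 2 both at the limit, there is no ground in the measured numbers for expecting the change from compound 2 to compound 3 to move the lethal concentration beyond the scatter in either direction; the expected step is a number no higher from compound 2 to compound 3 (the limit leaves the size open). Compound 3 is accordingly estimated at 100000 nM, with a range from 30000 nM to 300000 nM, and most likely reported again only as a limit.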

Compound 3, concentration lethal to 50% of the cells: > 100000 nM
Compound 3: no number, only a limit (the forecaster's own chance of this, stated with the estimate: 70%); the middle value sits exactly at the limit.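

Compound 2 and compound 3 both stand at a limit and give no number, so no step can be read between them: the limit of > 100000 nM in this assay, at which 3 of the 3 values shown sit.

The compounds shown leave open whether the group on the amine nitrogen in the ring changes the lethal concentration at all.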